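The compounds below may be only part of what the source reports. "The series", "measured", "known", "first", "only" and "open" are said of these compounds alone.

Measured so far in an assay on isolated protein for inhibition of matrix metalloproteinase-9 (Homo sapiens); on this read-out higher numbers stand for weaker inhibition and lower numbers for stronger inhibition:
- compound 1, `C=C[C@@H]1OC(CCCCC)=N[C@H]1CO`: > 2000000 nM
- compound 2, `C=C[C@@H]1OC(c2ccc(-c3ccccc3)cc2)=N[C@H]1Sc1ccccc1`: > 100000 nM
- compound 3, `C=C[C@@H]1OC(c2ccc(-c3ccccc3)cc2)=N[C@H]1CO`: 24000 nM

The value of compound 1 is a limit of this assay, not a number. The value of compound 2 is likewise a limit, not a number. Compound 3 is the only one of the three with a measured number, and the step from compound 2 to compound 3 is an at least 4.1-fold lower number from compound 2 to compound 3 (0.61 log units; beyond the scatter), so the exchange on the saturated ring carbon moves the series off the limit. Going by the values given here, the values of compound 1 and compound 3 also show that the group on the other ring carbon matters, though no step is worked out for that pair.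

Compound 4, `C=C[C@@H]1OC(c2ccc(Br)cc2)=N[C@H]1Sc1ccccc1`, is not yet measured. It keeps the phenylsulfanyl of compound 2 and differs from compound 2 only as bromo in place of phenyl on an aromatic carbon. Among the compounds with values here, no measured step touches this position in this assay, so there is nothing to set the size of the change. Since compound 2 already sits at a limit in this assay, compound 4 is expected to stay in that region too, with a step that the limit leaves unreadable from compound 2 to compound 4 as the estimated step. The estimate for compound 4 is 150000 nM, in the range 60000 nM to 400000 nM.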

Compound 4, inhibition constant: 94000 nM
Compound 4: middle estimate off by 1.6-fold (0.20 log units), on the high side, and the stated range covers the measured number.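

In this assay compound 4 gives a measured number, 94000 nM. The phenylsulfanyl group therefore does not by itself hold a compound at a limit, which compound 2 alone could not show. Bromo, a single heavy atom, can stand in place of the six-carbon phenyl, para to a large group, and the read-out still returns a number: the step is an at least 1.0-fold lower number from compound 2 to compound 4 (0.02 log units; that floor lies within the scatter), which gives a floor only and sets no direction for the exchange. The true size of this step stays unreadable because the comparison rests on a limit, not a number, for compound 2: the limit of > 100000 nM in this assay, at which 1 of the 4 values shown sits.

From the compounds shown here alone, it remains open whether bromo and phenyl differ at all at this aromatic carbon, and whether hydroxymethyl on the saturated ring carbon and bromo on the aromatic carbon would combine to give a lower number than compound 3 shows. Also open, going by these compounds, is how a carboxylic acid or an amine in place of bromo on the same aromatic carbon would read in this assay.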